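A few compounds are considered here, and "the series" means these few. Any claim that something is new, unique, unknown or untested is made for them only; others in the source may bear on it.

Measured so far in a functional assay on CHO-K1 cells for antagonist activity at transient receptor potential cation channel subfamily V member 1 (Homo sapiens), read by FLIPR; on this read-out higher numbers stand for weaker inhibition and lower numbers for stronger inhibition:
compound 1, `CC(C(=O)NCc1ccc(C(F)(F)F)nc1NCc1ccc(Cl)cc1)c1ccc(NS(C)(=O)=O)c(F)c1`: 414 nM
compound 2, `CC(C(=O)NCc1ccc(C(F)(F)F)nc1N(C)c1ccccc1)c1ccc(NS(C)(=O)=O)c(F)c1`: 57.4 nM
compound 3, `CC(C(=O)NCc1ccc(C(F)(F)F)nc1N1CC=CCC1)c1ccc(NS(C)(=O)=O)c(F)c1`: 12.1 nM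

Compound 3 gives the lowest number of the three and so the strongest inhibition in this assay; the gaps are a 4.7-fold lower number from compound 2 to compound 3 (0.68 log units; beyond the scatter) and a 34-fold lower number from compound 1 to compound 3 (1.53 log units; beyond the scatter). Compound 4, `CC(C(=O)NCc1ccc(C(F)(F)F)nc1N1CCC(C)(C)CC1)c1ccc(NS(C)(=O)=O)c(F)c1`, differs from it in one place: a group of 8 heavy atoms (7 carbon, 1 nitrogen; one six-membered non-aromatic ring with 1 hetero atom) in place of a group of 6 heavy atoms (5 carbon, 1 nitrogen; one six-membered non-aromatic ring with 1 hetero atom), on an aromatic carbon. Both measured steps swap an aromatic ring for this six-membered non-aromatic ring; neither compares two such non-aromatic rings, so they bear only loosely on the present change. The 4,4-dimethylpiperidin-1-yl group is expected to keep compound 4 near compound 3, with the step of a 1.2-fold higher number from compound 3 to compound 4 (0.09 log units; within the scatter) estimated to fall within the scatter. Compound 4 is therefore estimated at 15 nM, with a range from 5 nM to 45 nM.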

Compound 4, half-maximal inhibitory concentration: 8 nM
For compound 4 the middle estimate is 1.9-fold (0.27 log units) above the measured one; low and high end bracket the measured number.
By their numbers in this assay, from the lowest: compounds 4 and 3 (each within the scatter of the next); then compound 2; then compound 1.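

Replacing the ring of compound 3 with the larger 4,4-dimethylpiperidin-1-yl group on this aromatic carbon next to the ring nitrogen gives no clear shift in this assay (a 1.5-fold lower number from compound 3 to compound 4 (0.18 log units; within the scatter)), so the position accepts either non-aromatic ring, with or without the ring double bond. Compound 4 also keeps the advantage of a non-aromatic ring over methyl(phenyl)amino (a 7.2-fold lower number from compound 2 to compound 4 (0.86 log units; beyond the scatter)) and over (4-chlorobenzyl)amino (a 52-fold lower number from compound 1 to compound 4 (1.71 log units; beyond the scatter)). Nothing in hand explains these steps. Still open, going by these compounds, is how plain piperidine, the smaller pyrrolidine or morpholine, with its ring oxygen, would compare at this position.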